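Dihydroxybenzyl in place of fluorobenzyl on the shared core

A few compounds are considered here, and "the series" means these few. Any claim that something is new, unique, unknown or untested is made for them only; others in the source may bear on it.

Measured compounds:
- compound 1 `OC[C@H]1O[C@@H](n2cnc3c(NCc4ccccc4F)ncnc32)[C@H](O)[C@@H]1O`: 33200 nM
- compound 2 `OC[C@H]1O[C@@H](n2cnc3c(NCc4ccc(Cl)cc4Cl)ncnc32)[C@H](O)[C@@H]1O`: 106000 nM
- compound 3 `OC[C@H]1O[C@@H](n2cnc3c(NCc4ccc(F)cc4F)ncnc32)[C@H](O)[C@@H]1O`: 9600 nM

In a functional assay on K562 cells (Homo sapiens) for antiproliferative activity, with a stated time of 72 h (on this read-out lower numbers stand for stronger inhibition and higher numbers for weaker inhibition), compound 1 gives 33200 nM, the second highest of the three numbers. Compound 2 sits a 3.2-fold higher number from compound 1 to compound 2 (0.50 log units; beyond the scatter), and compound 3 sits a 3.5-fold lower number from compound 1 to compound 3 (0.54 log units; beyond the scatter); the two substituted benzyl groups are separated by an 11-fold lower number from compound 2 to compound 3 (1.04 log units; beyond the scatter).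

Compound 4 `OC[C@H]1O[C@@H](n2cnc3c(NCc4cccc(O)c4O)ncnc32)[C@H](O)[C@@H]1O` differs from compound 1 by 2,3-dihydroxyphenyl in place of 2-fluorophenyl on a saturated chain carbon bound to a nitrogen on an aromatic ring. Within the data shown here, no measured step exchanges a halogen for a hydroxyl group, so the known steps bear on this change only loosely: they show that the benzyl substitution pattern moves this assay by modest to large amounts in either direction, with the smaller halogen giving the lower number and the larger halogens the higher. A step of modest size is expected, its direction uncertain, and the estimate is placed near compound 1 with a wide range. Compound 4 is expected to give 40000 nM, between 10000 nM and 160000 nM, corresponding to a 1.2-fold higher number from compound 1 to compound 4 (0.08 log units; within the scatter).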

Compound 4, half-maximal inhibitory concentration: 25800 nM
The estimate for compound 4 lay 1.6-fold (0.19 log units) above the measured number; the range from low to high includes it.
By their numbers in this assay, from the lowest: compound 3; then compounds 4 and 1 (each within the scatter of the next); then compound 2.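

In this assay the swap to 2,3-dihydroxyphenyl on a saturated chain carbon bound to a nitrogen on an aromatic ring leaves the number within the scatter, with a 1.3-fold lower number from compound 1 to compound 4 (0.11 log units; within the scatter) as the step, so this place accepts hydroxyl groups as well as a fluoro group. The same group sits on neither extreme of the halogen set, with a 2.7-fold higher number from compound 3 to compound 4 (0.43 log units; beyond the scatter) on one side and a 4.1-fold lower number from compound 2 to compound 4 (0.61 log units; beyond the scatter) on the other, and so does not extend the range those compounds span. No measurement at hand accounts for these differences.

Still open, as far as these compounds go, is whether a single hydroxyl group, or a methoxy group in its place, gives a number like that of compound 4. Also open, from the compounds shown here alone, is whether 2,4-dihydroxyphenyl would come closer to compound 3 than 2,3-dihydroxyphenyl does.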